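Adding one chloro to a cytotoxic compound

This account rests on a few compounds, and the source may have more. Where it says the series, first, only, none or still open, it means among the compounds named here.

Compound 1 `COc1ccc(C2=C(c3cc(OC)c(OC)c(OC)c3)C(=O)C(OC(C)=O)C2)cc1` - "not determined" (no result reported)
Compound 2 `COc1ccc(C2=C(c3cc(OC)c(OC)c(OC)c3)C(=O)C(O)C2)cc1` - 6.3 ug/mL

Within the data shown here, in an ADME assay on HEK293 cells (Homo sapiens) for cytotoxicity, read by MTT assay, with a stated time of 72 h (a lower number here means a stronger inhibitor, a higher number a weaker inhibitor), compound 2 gives 6.3 ug/mL as the only actual number, since the other measured compound has no result. Compound 2 therefore cannot yet be ranked against anything. Compound 3 `COc1ccc(C2=C(c3cc(OC)c(OC)c(OC)c3)C(=O)C(O)C2)cc1Cl` keeps the shared core and changes in a single place, described as chloro in place of hydrogen on an aromatic carbon in the count of atoms. Put simply, chloro takes the place of hydrogen on an aromatic carbon, so 4-methoxyphenyl becomes 3-chloro-4-methoxyphenyl. Among the measured compounds shown here, no pair of measured compounds shows what such a swap does here, so this expectation rests on very little. The expected change is a 1.3-fold lower number from compound 2 to compound 3 (0.10 log units; within the scatter) and would be a small move towards stronger inhibition, possibly no larger than the usual scatter. The estimated value for compound 3 is 5 ug/mL with an expected range from 1.5 ug/mL to 15 ug/mL in repeated measurements.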

Compound 3, half-maximal inhibitory concentration: > 100 ug/mL
Compound 3 ended at the assay's limit; the forecaster's own chance of this, stated with the estimate: 5%; middle value at least 20-fold (1.30 log units) away from the limit.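

In this assay, chloro in place of hydrogen on an aromatic carbon, ortho to a methoxy group, proves to be no small change: it gives an at least 15-fold higher number from compound 2 to compound 3 (1.20 log units; beyond the scatter). This position on the 4-methoxyphenyl group is therefore sensitive, as a single added heavy atom moves the result strongly towards weaker inhibition. From the compounds shown here alone, compound 3 carries a limit of the assay rather than a number, so the full size of the step stays unknown: the limit of > 100 ug/mL in this assay, at which 1 of the 3 values shown sits.

Only one replacement at this carbon is shown, so it remains open whether the loss belongs to chloro in particular or would also follow from a group such as fluoro, methyl or an amine. Nor do these compounds show whether the same swap would act alike at any other place on the shared core.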